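The compounds below may be only part of what the source reports. "The series", "measured", "known", "first", "only" and "open" are said of these compounds alone.

Working notes on the series. In a functional assay for inhibition, with Homo sapiens as the target (a higher number here means weaker binding, a lower number tighter binding), compound 1 `O=C(O)CC/C=C\CC1COC(c2ccc([N+](=O)[O-])cc2)OC1c1cccnc1` gives 933 nM, compound 2 `O=C(O)CC/C=C\CC1COC(c2cccs2)OC1c1cccnc1` gives 1000 nM and compound 3 `Cc1ccc(OC(C)(C)C2OCC(C/C=C\CCC(=O)O)C(c3cccnc3)O2)cc1` gives 631 nM. These three numbers all lie within the usual scatter of one another, so compound 3 cannot be separated from the other two.

The next compound to read is compound 4 `CC(C)(Sc1ccccc1)C1OCC(C/C=C\CCC(=O)O)C(c2cccnc2)O1`, which differs from compound 3 in one place: phenylsulfanyl in place of 4-methylphenoxy on a saturated chain carbon bound to two saturated chain carbons and a saturated ring carbon. The exchange is phenylsulfanyl in place of 4-methylphenoxy on a saturated chain carbon bound to two saturated chain carbons and a saturated ring carbon.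

Within the data shown here, no measured step covers this exchange. The nearest evidence is a 1.1-fold higher number from compound 1 to compound 2 (0.03 log units; within the scatter), where thiophen-2-yl replaces 4-nitrophenyl on a saturated ring carbon. That step is a different exchange at a different place, so it bears only indirectly. Compound 3, at 631 nM, also stays within the scatter of both other compounds despite its different substituent. On this small set, a step beyond the scatter is not expected in this assay, and no direction can be assigned. The expected change is a 1.1-fold higher number from compound 3 to compound 4 (0.05 log units; within the scatter), which would stay within the scatter. For compound 4 the estimated value is 700 nM, with an expected range of 300 nM to 1600 nM.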

Compound 4, dissociation constant: 200 nM
Compound 4: middle estimate off by 3.5-fold (0.54 log units), on the high side, and the stated range ends above it.
By their numbers in this assay, from the lowest: compound 4; then compounds 3, 1 and 2 (each within the scatter of the next).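

In this assay, phenylsulfanyl in place of 4-methylphenoxy on a saturated chain carbon bound to two saturated chain carbons and a saturated ring carbon gives a 3.2-fold lower number from compound 3 to compound 4 (0.50 log units; beyond the scatter) and so separates two compounds that share the rest of their structure. Among these compounds, earlier, the only measured exchange gave a 1.1-fold higher number from compound 1 to compound 2 (0.03 log units; within the scatter) and left open whether the group on the saturated ring carbon mattered at all; the whole group there now counts, with (a 5.0-fold lower number from compound 2 to compound 4 (0.70 log units; beyond the scatter)) and (a 4.7-fold lower number from compound 1 to compound 4 (0.67 log units; beyond the scatter)) both printed beyond the scatter, so compound 4 has the lowest number of the four. Nothing at hand gives a reason for this gain.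

The exchange from compound 3 to compound 4 alters both the linking atom and the methyl group on the ring, so the compounds shown cannot say which of the two carries the step. Phenoxy and 4-methylphenylsulfanyl at this position would separate the two, and a sulfonyl or an amine as the link would show whether the step depends on sulfur in its sulfanyl form.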